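Rigid cyclopropane amide replaces a flexible amide chain

This account rests on a few compounds, and the source may have more. Where it says the series, first, only, none or still open, it means among the compounds named here.

Compound 1: `Cc1nc(-c2ccc(C(F)(F)F)cc2)sc1CNc1ccc(CC(=O)O)cc1`, < 10000 nM
Compound 2: `Cc1nc(-c2ccc(C(F)(F)F)cc2)sc1CNc1ccc(OCC(=O)O)cc1`, 288 nM
Compound 3: `Cc1nc(-c2ccc(C(F)(F)F)cc2)sc1CNc1ccc(CCC(=O)NC(C)C)cc1`, 100 nM

In a functional assay on CHO cells for agonist activity at Free fatty acid receptor 1 (Homo sapiens) (on this read-out lower numbers stand for an effect already at smaller amounts and higher numbers for an effect only at larger amounts of compound), compound 3 stands with the lowest number among the two values that are numbers. The value of compound 1 is a limit of the assay, not a number (the limit of < 10000 nM in this assay, at which 1 of the 3 values shown sits). Among the compounds with values here, the one readable step, a 2.9-fold lower number from compound 2 to compound 3 (0.46 log units; beyond the scatter), favours the amide-bearing chain over the acid ether. Compound 4 `Cc1nc(-c2ccc(C(F)(F)F)cc2)sc1CNc1ccc([C@H]2C[C@@H]2C(N)=O)cc1` changes that chain: 2-carbamoylcyclopropyl in place of 2-(isopropylcarbamoyl)ethyl on an aromatic carbon. Within the data shown here, the ring shortens the link and removes the isopropyl group, for which no measured step gives guidance, so only a modest loss is expected, a 2.2-fold higher number from compound 3 to compound 4 (0.34 log units; beyond the scatter). Compound 4 is therefore estimated at 220 nM, within 60 nM to 800 nM.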

Compound 4, half-maximal effective concentration: 4.47 nM
Compound 4: the middle estimate sits 49-fold (1.69 log units) above what was measured, and the stated range ends above it.
By their numbers in this assay, from the lowest: compound 4; then compound 3; then compound 2.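

At this place, on an aromatic carbon para to a large group, 2-carbamoylcyclopropyl gives a 22-fold lower number from compound 3 to compound 4 (1.35 log units; beyond the scatter), a far larger change than the earlier readable step showed. The same group also gives a 64-fold lower number from compound 2 to compound 4 (1.81 log units; beyond the scatter). The step from compound 1 cannot be read: the limit of < 10000 nM in this assay, at which 1 of the 4 values shown sits.

The ring and the loss of the isopropyl group arrive together in compound 4, so the compounds shown do not separate them. Going by these compounds, a plain carbamoyl on an ethyl chain, or a carboxylic acid on the cyclopropyl ring, remains open.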